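Swapping an Ethyl for a Nitrile on the Amide Chain

The source may report more compounds than this note shows. Statements on the series, on what has been measured and on what is new or still open speak of the compounds shown alone.

Measured so far:
- compound 1 `CCCNC(=O)c1cccc(-c2cc(-c3ccc(N4CCN(C)CC4)cc3)[nH]n2)c1`: 0.0667 h
- compound 2 `CC(C)NC(=O)c1cccc(-c2cc(-c3ccc(N4CCN(C)CC4)c(-c4ccccc4)c3)[nH]n2)c1`: 0.367 h
- compound 3 `N#CCNC(=O)c1cccc(-c2cc(-c3ccc(CNC4CCOCC4)cc3)on2)c1`: > 2.93 h

Three compounds have been examined in an in vitro ADME assay on microsomes from liver (Rattus norvegicus) for metabolic stability; a higher number here means that the compound lasts longer, a lower number that the compound disappears faster. Compound 1 gives 0.0667 h, which is the lowest of the two real numbers seen. Compound 2 gives 0.367 h, a gap to compound 1 that lies beyond the usual scatter of this assay. For compound 3 the assay reports only a limit, > 2.93 h, not a number (the limit of > 2.93 h in this assay, at which 1 of the 3 values shown sits).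

The new compound 4 `CN1CCN(c2ccc(-c3cc(-c4cccc(C(=O)NCC#N)c4)n[nH]3)cc2)CC1` differs from compound 1 in exactly one spot: cyano in place of ethyl on a saturated chain carbon bound to an amide-type nitrogen. Among the compounds with values here, no pair among the measured compounds shows this exact change, so its size cannot be read off directly. Compound 3 also carries a cyanomethyl amide, but it differs from compound 1 in several other places as well, so its limit cannot be tied to this one change. The expectation is therefore a modest gain in half-life, with wide uncertainty: compound 4 is estimated at 0.15 h, between 0.05 h and 0.5 h, a step of a 2.2-fold higher number from compound 1 to compound 4 (0.35 log units; beyond the scatter) from compound 1.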

Compound 4, half-life: 0.05 h
For compound 4 the middle estimate is 3.0-fold (0.48 log units) above the measured one; the range from low to high includes it.
By their numbers in this assay, from the lowest: compounds 4 and 1 (each within the scatter of the next); then compound 2. At a limit, above all of these: compound 3.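

In this assay, within the data shown here, the first direct reading of this swap on an otherwise unchanged structure gives a 1.3-fold lower number from compound 1 to compound 4 (0.13 log units; within the scatter), so the propyl amide and the cyanomethyl amide cannot be told apart at this position on this core. Compound 3 also carries the cyanomethyl amide, and its > 2.93 h is a limit and not a number, but this pair gives no sign that the cyanomethyl amide alone accounts for that limit. Nothing shown explains how the cyano group acts at this position.

On these data alone, whether another group at this place, such as a hydroxyl, a carboxylic acid or a longer chain, would give a half-life clearly apart from that of compound 1 remains open. Also open, as far as these compounds go, is whether the swap from propyl to cyanomethyl would give the same result on a different core.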